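Swapping the ortho group on the shared core

The source may hold more compounds than are shown below. What is called first, only, known or untested is meant among the compounds shown, and "the series" means these compounds.

Measured compounds:
- compound 1, `Cc1cc(=O)n(-c2ccccc2OC(F)(F)F)nc1C(=O)Nc1ccc(Oc2ncnc3c2ccn3C)cc1`: 27000 nM
- compound 2, `Cc1cc(=O)n(-c2ccccc2C(F)(F)F)nc1C(=O)Nc1ccc(Oc2ncnc3c2ccn3C)cc1`: 7840 nM

Both compounds were tested in a functional assay on MCF7 cells (Homo sapiens) for cytotoxicity, read by MTT assay, with a stated time of 72 h; a higher number here means a weaker inhibitor, a lower number a stronger inhibitor. Compound 1 gives 27000 nM and compound 2 gives 7840 nM. The one step so far, a 3.4-fold lower number from compound 1 to compound 2 (0.54 log units; beyond the scatter), makes compound 2 the lower of the two numbers shown, with compound 1 as its only neighbour.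

Compound 3, `Cc1cc(=O)n(-c2ccccc2Cl)nc1C(=O)Nc1ccc(Oc2ncnc3c2ccn3C)cc1`, is not yet measured. It differs from compound 2 by chloro in place of trifluoromethyl on an aromatic carbon, sitting on an aromatic carbon of a six-membered aromatic ring of carbon only, ortho to a large group. Among the measured compounds shown here, no measured step removes a trifluoromethyl for a chloro, so the single step in this set does not bear directly on this change; it only shows that exchanging one small group at this place moved the number by a modest amount. For the measured compounds named here, with no step of the same kind to lean on, the expectation for compound 3 is a number close to that of compound 2, with a wide range around it and no step beyond the scatter in either direction, that is a 1.0-fold higher number from compound 2 to compound 3 (0.01 log units; within the scatter). Compound 3 is therefore estimated at 8000 nM, within 2500 nM to 25000 nM.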

Compound 3, half-maximal inhibitory concentration: 4130 nM
Estimate against measurement, compound 3: 1.9-fold (0.29 log units) above; the measured number falls inside the stated range.
By their numbers in this assay, from the lowest: compounds 3 and 2 (each within the scatter of the next); then compound 1.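

In this assay the exchange of trifluoromethyl for chloro on this aromatic carbon gives a 1.9-fold lower number from compound 2 to compound 3 (0.28 log units; within the scatter), so this assay does not separate the two groups, even though one has four heavy atoms and the other a single chlorine. The other new step, a 6.5-fold lower number from compound 1 to compound 3 (0.82 log units; beyond the scatter), lies beyond the scatter, as does the earlier step from compound 1 to compound 2, so compounds 2 and 3 stand together and compound 1, with trifluoromethoxy, stands apart with the highest number of the three. No measurement here accounts for this grouping.

The compounds shown leave open what happens at this place with a group of another kind, such as an amine, a carboxylic acid or a longer chain, and whether any of these would bring the number clearly below those of compounds 2 and 3. They also leave open what plain hydrogen at this place would give, and so whether any of the three groups helps at all compared with having no group there.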